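Pyrazolylmethyl ether returns to a purine-bearing lactam series

A few compounds are considered here, and "the series" means these few. Any claim that something is new, unique, unknown or untested is made for them only; others in the source may bear on it.

Measured compounds:
compound 1 `O=C1/C(=C/NCCCO)C(c2ccccc2)=NN1c1nc2ccccc2s1` — 200 nM
compound 2 `Cc1cc(C)n(CCOC2CC(=O)Nc3c2c(C)nn3-c2ncnc3nc[nH]c23)n1` — 16 nM
compound 3 `Cc1nn(-c2ncnc3nc[nH]c23)c2c1C(OCc1ccccc1F)CC(=O)N2` — 4 nM

In a functional assay on HEK293 cells for agonist activity at G-protein coupled receptor 39 (Homo sapiens), read by scintillation proximity assay and inositol phosphate accumulation, with a stated time of 75 min, in the presence of a further agent that is not named here (a higher number here means that more compound is needed for the effect, a lower number that less compound is needed), compound 3 gives the lowest number of the three. Compound 2 stands nearest to it, and compound 1, built on a different core, is furthest away. Among the compounds with values here, the single step that connects compound 2 with compound 3, a 4.0-fold lower number from compound 2 to compound 3 (0.60 log units; beyond the scatter), replaced a (3,5-dimethyl-1H-pyrazol-1-yl)methyl group by 2-fluorophenyl.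

Compound 4 `Cc1nn(-c2ncnc3nc[nH]c23)c2c1C(OCCn1nccc1C)CC(=O)N2` reverses the direction of that change in part: (5-methyl-1H-pyrazol-1-yl)methyl in place of 2-fluorophenyl on a saturated chain carbon bound to an oxygen on a saturated carbon. Within the data shown here, the entering group is again a pyrazolylmethyl, related to the one carried by compound 2 but differing in its methyl pattern. The step from compound 2 to compound 3 is therefore the only one that bears on this change, and it suggests that undoing it should raise the number again, though perhaps not fully, since the group is not identical. Compound 4 is expected to give 10 nM, within 4 nM to 30 nM, an estimated step of a 2.5-fold higher number from compound 3 to compound 4 (0.40 log units; beyond the scatter).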

Compound 4, half-maximal effective concentration: 10 nM
Beside the measured number, compound 4's estimate shows no gap at the digits printed; the range from low to high includes it.
By their numbers in this assay, from the lowest: compound 3; then compounds 4 and 2 (each within the scatter of the next); then compound 1.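

In this assay, the pyrazolylmethyl group again gives a higher number than 2-fluorophenyl on a saturated chain carbon bound to an oxygen on a saturated carbon, with a 2.5-fold higher number from compound 3 to compound 4 (0.40 log units; beyond the scatter) now measured directly against the 2-fluorophenyl compound. Hydrogen in place of methyl on an aromatic carbon gives a 1.6-fold lower number from compound 2 to compound 4 (0.20 log units; within the scatter) and so leaves this methyl change without a measurable effect in this pair, which shows that the pyrazole can lose that methyl and still stay apart from 2-fluorophenyl. Nothing presented here accounts for either step.

From the compounds shown here alone, it remains open whether an unsubstituted phenyl, an amine or a carboxylic acid on the same saturated chain carbon would give a number nearer that of compound 3 or compound 4. The data also leave open whether a longer chain bearing the pyrazole would keep the number seen for compound 4.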